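Replacing thiophene with phenyl on a weak chlorinated amide

The source may hold more compounds than are shown below. What is called first, only, known or untested is meant among the compounds shown, and "the series" means these compounds.

Compound 1 `O=C(Nc1cccc(-c2ccsc2)c1)C(Cl)Cl` carries a chlorinated amide on its core together with a thiophen-3-yl group. In a functional assay on A549 cells (Homo sapiens) for cytotoxicity, read by MTT assay, with a stated time of 68 h (a higher number here means a weaker inhibitor, a lower number a stronger inhibitor), compound 1 reaches only the limit of the assay, > 50000 nM, so this is a limit rather than a measured number. Compound 1 stands on (the limit of > 50000 nM in this assay, at which 1 of the 2 values shown sits). The other measured compound, compound 2 `O=C(Nc1cc(-c2ccc(OC3CCCCO3)cc2)cc(-c2ccc(OC3CCCCO3)cc2)c1)C(Cl)Cl`, is built differently, with two substituted phenyl groups on the core, and in this assay compound 2 gives 2750 nM. The not yet measured compound 3 `O=C(Nc1cccc(-c2ccccc2)c1)C(Cl)Cl` differs from compound 1 in one place: phenyl in place of thiophen-3-yl on an aromatic carbon. Among the measured compounds shown here, no measured pair shows what this exchange alone does in this assay; compound 2 differs from both in more than one place. The change is expected to stay within the usual scatter, a step that the limit leaves unreadable from compound 1 to compound 3. Compound 3 is therefore expected to give 60000 nM, within a range from 15000 nM to 200000 nM, with a real chance that only a limit is reported again.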

Compound 3, half-maximal inhibitory concentration: 8900 nM
Compound 3: middle estimate off by 6.7-fold (0.83 log units), on the high side; measured number below the stated range.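

On this aromatic carbon of the shared core, the choice of ring matters: in this assay, phenyl in place of thiophen-3-yl gives an at least 5.6-fold lower number from compound 1 to compound 3 (0.74 log units; beyond the scatter). Among the compounds shown here, this is the first exchange of a single group that can be read here, and it moves a compound with no measured number to one with a measured number. The true size of the step stays unknown, because compound 1 carries a limit and not a number: the limit of > 50000 nM in this assay, at which 1 of the 3 values shown sits.

The compounds shown do not tell whether phenyl itself is the best ring at this place, or how a pyridine ring, or a phenyl carrying a methoxy group or an amine, would behave there. One exchange on one core also leaves open whether the same step would appear on a different core.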